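Extending the oxadiazole methyl to a methoxyphenyl group

This account rests on a few compounds, and the source may have more. Where it says the series, first, only, none or still open, it means among the compounds named here.

Measured compounds in a functional assay on MIA PaCa-2 cells (Homo sapiens) for antiproliferative activity, read by WST assay, with a stated time of 72 h; a lower number here means a stronger inhibitor, a higher number a weaker inhibitor:
- compound 1 `COc1ccc2[nH]c(-c3nc(C)no3)cc2c1`: > 50000 nM
- compound 2 `Cc1noc(-c2cc3cc(F)ccc3[nH]2)n1`: 19400 nM
- compound 3 `Cc1noc(-c2cc3cc(Cl)ccc3[nH]2)n1`: > 50000 nM

Compound 1 reaches only the limit of this assay, so its result is > 50000 nM rather than a number. Compound 3 likewise reaches only a limit, giving > 50000 nM in this assay. Among the measured compounds shown here, compound 2 is the one compound with a readable number, 19400 nM. Among the measured steps, an at least 2.5-fold lower number from compound 1 to compound 2 (0.41 log units; beyond the scatter), and an at least 2.5-fold higher number from compound 2 to compound 3 (0.41 log units; beyond the scatter), while a step that the two limits leave unreadable from compound 1 to compound 3. Two of the three results sit at the limit of > 50000 nM in this assay, at which 2 of the 3 values shown sit, which leaves the standing of compound 1 known only as a limit.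

Compound 4 `COc1ccc(-c2noc(-c3cc4cc(OC)ccc4[nH]3)n2)cc1` changes a different part of the molecule: 4-methoxyphenyl in place of methyl on an aromatic carbon. For the measured compounds named here, no measured step touches this position; all three measured steps exchange the group on the other ring. There is therefore no evidence on which to expect a step of any particular size or direction in this assay for this change. The estimate for compound 4 is 20000 nM, within 3000 nM to 50000 nM. This estimate means an at least 2.5-fold lower number from compound 1 to compound 4 (0.39 log units; beyond the scatter), and it is held loosely, with a substantial chance that compound 4, like compound 1, reports only a limit.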

Compound 4, half-maximal inhibitory concentration: 5600 nM
For compound 4 the middle estimate is 3.6-fold (0.55 log units) above the measured one, within the range that was stated.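

All three earlier steps exchanged the group on the other ring, so nothing yet showed whether the aromatic carbon of the five-membered ring, which carries the methyl in compound 1, has any bearing on the result. In this assay, placing 4-methoxyphenyl on that carbon gives an at least 8.9-fold lower number from compound 1 to compound 4 (0.95 log units; beyond the scatter), so this position does matter, and it tolerates a far larger group that brings a six-membered aromatic ring, with compound 4 reaching a readable 5600 nM. Compound 1 gives only a limit, so this step is a minimum and its full size cannot be read: the limit of > 50000 nM in this assay, at which 2 of the 4 values shown sit.

The compounds shown leave open whether the gain comes from the six-membered aromatic ring itself or from its methoxy group, and how a plain phenyl, an amine or a carboxylic acid at this carbon would compare. It also remains open whether the same exchange would lower the number to a similar extent on the fluoro compound, compound 2, since the change is shown only on the core of compound 1.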